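Methoxy in Place of Fluoro: What Compound 4 May Show

This account rests on a few compounds, and the source may have more. Where it says the series, first, only, none or still open, it means among the compounds named here.

Three compounds have been measured in a functional assay on MCF7 cells (Homo sapiens) for cytotoxicity, read by sulforhodamine B assay, with a stated time of 48 h; a lower number here means a stronger inhibitor of growth, a higher number a weaker inhibitor of growth:

compound 1 `COc1ccc(-c2ccc(C)n2-c2ccc(-c3nc4ccccc4s3)cc2)cc1` gives 2780 nM in this assay.
compound 2 `COc1cc(-c2ccc(C)n2-c2ccc(-c3nc4ccccc4s3)cc2)cc(OC)c1OC` gives 2340 nM in this assay.
compound 3 `COc1cc(-c2ccc(C)n2-c2ccc(-c3nc4ccc(F)cc4s3)cc2)cc(OC)c1OC` gives 1410 nM in this assay.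

Compound 3 carries the lowest number of the three, yet its gaps to compound 2 and to compound 1 both lie within the scatter, so no order among them can be claimed. Among the compounds with values here, the one measured step that bears on the present change is a 1.7-fold lower number from compound 2 to compound 3 (0.22 log units; within the scatter), itself within the scatter. Compound 4 `COc1ccc2nc(-c3ccc(-n4c(C)ccc4-c4cc(OC)c(OC)c(OC)c4)cc3)sc2c1` differs from compound 3 by methoxy in place of fluoro on an aromatic carbon. Within the data shown here, no measured pair shows a methoxy at this place, so the data give no direction. The step from compound 3 to compound 4 in this assay is therefore expected to be a 1.3-fold higher number from compound 3 to compound 4 (0.11 log units; within the scatter), not beyond the scatter. Compound 4 is estimated at 1800 nM, with a range from 700 nM to 4500 nM.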

Compound 4, concentration for 50% growth inhibition: 920 nM
Estimate against measurement, compound 4: 2.0-fold (0.29 log units) above, and the stated range covers the measured number.
By their numbers in this assay, from the lowest: compounds 4, 3, 2 and 1 (each within the scatter of the next, the first and the last beyond it).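

In this assay, within the data shown here, the 6-methoxy-1,3-benzothiazol-2-yl group gives the first step at this position that lies beyond the scatter, a 2.5-fold lower number from compound 2 to compound 4 (0.41 log units; beyond the scatter) with methoxy in place of hydrogen. Against fluoro the change gives a 1.5-fold lower number from compound 3 to compound 4 (0.19 log units; within the scatter) and so leaves methoxy and fluoro unordered at this position. No measured evidence bears on why the numbers fall this way. The compounds shown leave open what an amine or a carboxylic acid would give at this position. They also leave open whether a longer chain such as ethoxy would keep the step seen with methoxy.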